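Adding a chloro group to compound 2

The compounds below may be only part of what the source reports. "The series", "measured", "known", "first", "only" and "open" are said of these compounds alone.

Compound 1 `O=C(CCl)Nc1ccc(C(=O)/C=C/c2cccc(Cl)c2)cc1`: 2010 nM
Compound 2 `O=C(CSC(=S)N[C@H]1CCOC1=O)Nc1ccc(C(=O)/C=C/c2ccccc2)cc1`: 24800 nM

In a functional assay on MGC-803 cells (Homo sapiens) for cytotoxicity, read by MTT assay, with a stated time of 72 h (a higher number here means a weaker inhibitor, a lower number a stronger inhibitor), compound 2 gives 24800 nM. This is the higher of the two numbers, which makes compound 2 the weaker inhibitor, and its gap to compound 1 lies beyond the usual scatter. Compound 3 `O=C(CSC(=S)N[C@H]1CCOC1=O)Nc1ccc(C(=O)/C=C/c2cccc(Cl)c2)cc1` is compound 2 with a single change: chloro in place of hydrogen on an aromatic carbon. Within the data shown here, no pair of measured compounds shows this change alone. Compound 1 also carries the 3-chlorophenyl group and gives 2010 nM, but it differs from compound 2 elsewhere too, so it offers only a weak hint. The estimated step of a 2.8-fold lower number from compound 2 to compound 3 (0.44 log units; beyond the scatter) is modest and points toward stronger inhibition. For compound 3 the expected value is 9000 nM, with an estimated range of 2500 nM to 30000 nM.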

Compound 3, half-maximal inhibitory concentration: 15600 nM
Estimate against measurement, compound 3: 1.7-fold (0.24 log units) below; measured number inside the range.
By their numbers in this assay, from the lowest: compound 1; then compounds 3 and 2 (each within the scatter of the next).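

In this assay, chloro in place of hydrogen on an aromatic carbon, meta to a large group, gives a 1.6-fold lower number from compound 2 to compound 3 (0.20 log units; within the scatter), so turning phenyl into 3-chlorophenyl has no effect that can be told apart from ordinary repeat variation in this pair. The other new comparison keeps the 3-chlorophenyl group and changes the saturated chain carbon bound to a carbonyl carbon, where the group bearing a five-membered non-aromatic ring replaces one chlorine atom and gives a 7.8-fold higher number from compound 1 to compound 3 (0.89 log units; beyond the scatter), a difference beyond the scatter. No measurement here explains either step.

From the compounds shown here alone, whether a fluoro, a methoxy or an amine on the same aromatic carbon would move the number remains open. So does the outcome of placing a carboxylic acid or a longer chain on the saturated chain carbon.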